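Acyl sulfonamide in place of sulfonamide on the benzoxazole-free core

The compounds below may be only part of what the source reports. "The series", "measured", "known", "first", "only" and "open" are said of these compounds alone.

Of the compounds shown here, two have been read in an ADME assay on the whole organism (plasma, Macaca fascicularis) for protein binding, read by LC-MS, using equilibrium dialysis and cassette dosing, with a stated time of 24 h, at a dose of 1 mg/kg by the oral route; on this read-out lower numbers stand for a smaller free fraction and higher numbers for a larger free fraction. Compound 1 `C[C@H](c1ccc(-c2ccccc2-c2nc(=O)o[nH]2)cc1)N(CC1CC1)c1nc2c(C(=O)O)cccc2o1` carries a carboxylic acid on its core and gives 0.0000851. Compound 2 `CCCCN(c1nc2c(NS(C)(=O)=O)cccc2o1)[C@H](C)c1ccc(-c2ccccc2-c2nnn[nH]2)cc1` carries a methanesulfonamido group in the matching place and gives 0.000203, the higher of the two numbers; compound 1 stands beneath it by a gap that is beyond the scatter. Among the compounds with values here, no pair of the measured compounds differs in one place only, so no single step can be read from them.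

Compound 3 `CCCCN(c1nc2c(C(=O)NS(C)(=O)=O)cccc2o1)[C@H](C)c1ccc(-c2ccccc2-c2nnn[nH]2)cc1` has not been measured in this assay. It differs from compound 2 in one place: (methylsulfonyl)carbamoyl in place of methanesulfonamido on an aromatic carbon. The change keeps a single hydrogen-bond donor and adds a carbonyl between the ring and the sulfonyl group.

The expectation for compound 3 is a lower unbound fraction than compound 2, a step of a 2.0-fold lower number from compound 2 to compound 3 (0.31 log units; beyond the scatter), moving toward the number of compound 1 rather than away from it. The estimate for compound 3 is 0.0001, with a range from 0.00004 to 0.00025.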

Compound 3, unbound fraction: 0.00103
For compound 3 the middle estimate is 10-fold (1.01 log units) below the measured one, and the stated range ends below it.
By their numbers in this assay, from the lowest: compound 1; then compound 2; then compound 3.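

In this assay, within the data shown here, (methylsulfonyl)carbamoyl in place of methanesulfonamido on this aromatic carbon gives a 5.1-fold higher number from compound 2 to compound 3 (0.71 log units; beyond the scatter), the first step that can be read at a single place. It shows that the free fraction responds to the group held on this carbon, even with the rest of compound 2 unchanged and a change as small as one added carbonyl and the atoms printed for the entering group. No measurement on hand accounts for the direction or size of this step.

From the compounds shown here alone, it remains open whether the rise belongs to the carbonyl alone or to the whole (methylsulfonyl)carbamoyl group, a question that a plain carboxamide or a phenylsulfonyl carbamoyl group on the same carbon would help to settle. Going by these compounds, it also remains open whether the step carries over to other parts of the series, for instance with a propyl chain in place of the butyl chain, since this single pair speaks only for the scaffold of compound 2.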